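Swapping a five-atom group for amino on compound 3

The source may hold more compounds than are shown below. What is called first, only, known or untested is meant among the compounds shown, and "the series" means these compounds.

Measured in a functional assay on NPC-TW01 cells (Homo sapiens) for inhibition, read by MTT assay, with a stated time of 72 h; on this read-out lower numbers stand for stronger inhibition of growth and higher numbers for weaker inhibition of growth:
compound 1 `Cc1ccc(-c2cc(N)n(-c3ccc(Br)cc3)n2)cc1`: 80200 nM
compound 2 `Cc1ccc(-c2nn(-c3cccc(Cl)c3)c(/N=C/N(C)C)c2C=O)cc1`: 7200 nM
compound 3 `Cc1ccc(-c2nn(-c3ccc(Br)cc3)c(/N=C/N(C)C)c2C=O)cc1`: 6000 nM

In this assay the nearest neighbour of compound 3 is separated from it by a 1.2-fold lower number from compound 2 to compound 3 (0.08 log units; within the scatter). Compound 2 and compound 3 both stand below compound 1, by a gap beyond the scatter.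

Compound 4 `Cc1ccc(-c2nn(-c3ccc(Br)cc3)c(N)c2C=O)cc1` differs from compound 3 at one place, on an aromatic carbon, where an amino group takes over from a group without a common name: one nitrogen atom in place of a group of 5 heavy atoms (3 carbon, 2 nitrogen; no ring), on an aromatic carbon.

Going by the values given here, the only measured step, a 1.2-fold lower number from compound 2 to compound 3 (0.08 log units; within the scatter), concerns the group on an aromatic nitrogen, so it says little about this change. Among the compounds with values here, no measured pair isolates the change. The closest guide is compound 1, which also carries amino and 4-bromophenyl groups but has no formyl group, and it gives 80200 nM. Compound 4 keeps the formyl group of compound 3 and shares the amino group of compound 1, so a value between those two is expected. The expected change is a 4.2-fold higher number from compound 3 to compound 4 (0.62 log units; beyond the scatter), towards weaker inhibition of growth and probably beyond the scatter. For compound 4 the estimated value is 25000 nM, with an expected range from 8000 nM to 80000 nM.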

Compound 4, concentration for 50% growth inhibition: 28200 nM
Estimate against measurement, compound 4: 1.1-fold (0.05 log units) below; low and high end bracket the measured number.
By their numbers in this assay, from the lowest: compounds 3 and 2 (each within the scatter of the next); then compound 4; then compound 1.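

In this assay, the group of 5 heavy atoms on this aromatic carbon now has a step of its own: with the formyl and 4-bromophenyl groups held constant, amino in its place gives a 4.7-fold higher number from compound 3 to compound 4 (0.67 log units; beyond the scatter) and so weaker inhibition of growth, a modest change beyond the scatter. Going by these compounds alone, compound 4 also gives the first isolated reading of the formyl group, as with the amino and 4-bromophenyl groups held constant, formyl in place of hydrogen gives a 2.8-fold lower number from compound 1 to compound 4 (0.45 log units; beyond the scatter), again modest and beyond the scatter. No measurement is available that would explain either step.

As far as these compounds go, whether a smaller substituted nitrogen group on this aromatic carbon, such as dimethylamino or acetamido, would keep the number close to that of compound 3 or leave it close to that of compound 4 stays open. From the compounds shown here alone, it is also open whether a nitrile or a carboxylic acid could stand in for the formyl group, and whether either step would be of the same size with 3-chlorophenyl on the ring nitrogen.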